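Adding a Second Methoxy to an Antiproliferative Oxadiazoline

The source may hold more compounds than are shown below. What is called first, only, known or untested is meant among the compounds shown, and "the series" means these compounds.

Of the compounds shown here, three have been measured in a functional assay on L1210 cells (Mus musculus) for antiproliferative activity, read by MTT assay, with a stated time of 72 h; a higher number here means a weaker inhibitor, a lower number a stronger inhibitor. Compound 1, `COc1ccccc1C1OC(c2cc(OC)c(OC)c(OC)c2)=NN1C(C)=O`, gives 48000 nM. Compound 2, `COc1cc(C2=NN(C(C)=O)C(c3ccccc3)O2)cc(OC)c1OC`, gives 6400 nM. Compound 3, `COc1ccc(C2=NN(C(C)=O)C(c3ccccc3OC)O2)cc1`, gives 5800 nM, which stands within the scatter of compound 2 and well apart from compound 1.

Between compound 2 and compound 1 the change is methoxy in place of hydrogen on an aromatic carbon; the step it made was a 7.5-fold higher number from compound 2 to compound 1 (0.88 log units; beyond the scatter). The difference between the cores of compound 2 and compound 3 is not broken down here.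

Compound 4, `COc1ccc(C2=NN(C(C)=O)C(c3cc(OC)ccc3OC)O2)cc1`, has not yet been measured. It differs from compound 3 by methoxy in place of hydrogen on an aromatic carbon. Within the data shown here, this is the same kind of change as the one from compound 2 to compound 1, not the same: in compound 1 the methoxy sits ortho to a large group, while in compound 4 it sits meta to a large group and para to a methoxy group. Among the measured compounds shown here, because the only measured instance of this kind of change, a 7.5-fold higher number from compound 2 to compound 1 (0.88 log units; beyond the scatter), weakened the inhibitor, compound 4 is expected to give a higher number than compound 3, though the different surroundings make the size uncertain. The expected step is a 2.6-fold higher number from compound 3 to compound 4 (0.41 log units; beyond the scatter). The estimate for compound 4 in this assay is 15000 nM, with a likely range from 5000 nM to 50000 nM.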

Compound 4, half-maximal inhibitory concentration: 500 nM
Beside the measured number, compound 4's estimate is 30-fold (1.48 log units) above it; the measured number lies below the stated range.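

In this assay the exchange of hydrogen for methoxy on an aromatic carbon gave a 12-fold lower number from compound 3 to compound 4 (1.06 log units; beyond the scatter) and thereby ran opposite to the earlier 7.5-fold higher number from compound 2 to compound 1 (0.88 log units; beyond the scatter) in this series. The change therefore did not carry from one core to the other with even its direction kept, and the gap between the two steps is larger than repeated measurement would produce: the same change on two cores in this assay, a 7.5-fold higher number (0.88 log units; beyond the scatter) from compound 2 to compound 1 and a 12-fold lower number (1.06 log units; beyond the scatter) from compound 3 to compound 4, 87-fold (1.94 log units) apart, beyond the scatter of two such steps. This does not show what sets the direction, for the two steps differ both in their cores and in the place of the new methoxy, which in compound 4 is meta to a large group and para to a methoxy group, and one step on each core cannot separate those two differences.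

The compounds shown leave open whether a methoxy in that same place on the core of compound 2 would also lower the number, which would tell the effect of the place from that of the core. They also leave open whether the lower number of compound 4 is particular to methoxy or would also appear with a hydroxy group, an ethoxy group or a fluorine atom on that carbon.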